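Swapping the Iodophenyl for a Methylphenyl in a Hydrazide

The compounds below may be only part of what the source reports. "The series", "measured", "known", "first", "only" and "open" are said of these compounds alone.

Measured compounds:
- Compound 1 `COc1ccccc1C(=O)N(NC(=O)c1ccccc1)C(C)(C)C`: 525 nM
- Compound 2 `CC(C)(C)N(NC(=O)c1ccccc1I)C(=O)c1ccccc1Cl`: 1290 nM

Both compounds were tested in an assay on cells for agonist activity at ecdysone receptor (Bombyx mori), read by a luciferase reporter, with a stated time of 24 h; a lower number here means that less compound is needed, a higher number that more compound is needed for the effect. Compound 1 gives 525 nM in this assay, and compound 2 gives 1290 nM. Compound 2 therefore stands at the higher of the two numbers, meaning more of it is needed than of compound 1, and the gap between them lies beyond the usual scatter of repeated measurements.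

The next compound, compound 3 `Cc1ccc(C(=O)NN(C(=O)c2ccccc2Cl)C(C)(C)C)cc1`, has not yet been measured. It keeps the core of compound 2 and changes one part: 4-methylphenyl in place of 2-iodophenyl on a carbonyl carbon. Among the measured compounds shown here, nothing is known from measured pairs about how such a swap shifts the read-out, so the expectation rests only on where compound 2 stands, which is at the weaker end of the two numbers so far.

With only that to go on, compound 3 is expected to need less compound than compound 2, a step of a 3.7-fold lower number from compound 2 to compound 3 (0.57 log units; beyond the scatter) in this assay. The estimate for compound 3 in this assay is 350 nM, with a range from 100 nM to 1200 nM.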

Compound 3, half-maximal effective concentration: 18.6 nM
Compound 3: the middle estimate sits 19-fold (1.27 log units) above what was measured, and the stated range ends above it.
By their numbers in this assay, from the lowest: compound 3; then compound 1; then compound 2.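

In this assay the swap of 2-iodophenyl for 4-methylphenyl, on a carbonyl carbon whose other neighbour is an amide-type nitrogen, gives a 69-fold lower number from compound 2 to compound 3 (1.84 log units; beyond the scatter) as a large step well beyond the usual scatter, so the read-out depends strongly on what this position carries. The two groups match in several counts, each having 7 heavy atoms, one six-membered aromatic ring of carbon only, and no hydrogen-bond donors or acceptors, so these counts do not separate them; they differ in iodine against a methyl carbon and in the numbers within their names. Nothing measured here accounts for the size of this step.

The change alters both the substituent and the numbered place it holds on the ring, so the compounds shown leave open which of the two matters, a question that 4-iodophenyl or 2-methylphenyl could help to settle. They also leave open how far the 4-methylphenyl result extends to other groups at the same place on the ring, such as an ethyl chain, an amine or a carboxylic acid.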